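Amide nitrogen substituent variation in the shared core series

The compounds below may be only part of what the source reports. "The series", "measured", "known", "first", "only" and "open" are said of these compounds alone.

Compound 1 `CCOc1nc2cccc(C(=O)Nc3ccc(OC)cc3)c2n1Cc1ccc(-c2ccccc2-c2nnn[nH]2)cc1` and compound 2 `CCOc1nc2cccc(C(=O)NCc3ccco3)c2n1Cc1ccc(-c2ccccc2-c2nnn[nH]2)cc1` share one core and differ only in the group on the amide-type nitrogen. In an assay on isolated protein for inhibition of NEDD8-activating enzyme E1 regulatory subunit (Homo sapiens), read by Western blot, with stated times of 10 min and 30 min, tested at 25 uM (on this read-out higher numbers stand for more inhibition at the one concentration tested (going by the name of the read-out) and lower numbers for less inhibition), compound 1 gives 25.8%, and in this assay compound 2 gives 37.5%. Going by the values given here, the step of a number 11.7 percentage points higher from compound 1 to compound 2 (beyond the scatter) is the only measured step so far. On these two numbers compound 2 stands highest, with compound 1 the nearest and lower by that step.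

Compound 3 `CCOc1nc2cccc(C(=O)NCCCCc3ccccc3)c2n1Cc1ccc(-c2ccccc2-c2nnn[nH]2)cc1` keeps the core and the amide of compound 2 and changes the group on the chain carbon bound to the amide-type nitrogen: 3-phenylpropyl in place of furan-2-yl on a saturated chain carbon bound to an amide-type nitrogen.

Among the compounds with values here, the one measured step replaced an aryl group on the nitrogen by a (furan-2-yl)methyl group and gave a modest rise; no measured step separates the furan-2-yl group from a 3-phenylpropyl group, so it bears on the new change only loosely. With the aromatic ring kept but moved further out on a longer chain, the expected step of a number 2.5 percentage points lower from compound 2 to compound 3 (within the scatter) is small, in either direction, and within the scatter. Compound 3 is therefore estimated at 35%, with a range from 20% to 50%.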

Compound 3, a percentage reported as inhibition, at one concentration (the size of the read-out at that concentration, not a potency): 64.6%
The estimate for compound 3 lay 29.6 percentage points below the measured number; measured number above the stated range.
By their numbers in this assay, from the lowest: compound 1; then compound 2; then compound 3.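

In this assay, 3-phenylpropyl in place of furan-2-yl on a saturated chain carbon bound to an amide-type nitrogen gives a number 27.1 percentage points higher from compound 2 to compound 3 (beyond the scatter) and places compound 3 highest of the three, with its steps to both others beyond the scatter. Against the aryl amide, 4-phenylbutyl in place of 4-methoxyphenyl on an amide-type nitrogen gives a number 38.8 percentage points higher from compound 1 to compound 3 (beyond the scatter), so this position can carry a long chain ending in a phenyl ring and the read-out moves strongly with what sits there, well past what the first pair of compounds suggested. Nothing at hand explains why this change raises the number.

Ring type and chain length change together in the step to compound 3, so the compounds shown leave open which of the two carries the rise. A benzyl group on the amide-type nitrogen, a 4-cyclohexylbutyl group, or a longer chain ending in phenyl would bear on that question and on whether the rise continues as the chain grows.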